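The source may report more compounds than this note shows. Statements on the series, on what has been measured and on what is new or still open speak of the compounds shown alone.

Among the measured compounds shown here, only one number is available in a functional assay on NCI-H1993 cells (Homo sapiens) for inhibition, read by CCK-8 assay, with a stated time of 72 h; a higher number here means a weaker inhibitor, a lower number a stronger inhibitor. Compound 3 `CCC(c1cc2cccnc2cc1F)n1cnc2ncc(-c3ccc(C(N)=O)c(F)c3)nc21` gives 226 nM, so it stands alone, with nothing to rank it against. Two relatives offer no numerical help. For compound 1 `CCC(c1ccc2ncccc2c1F)n1cnc2ncc(-c3ccncc3)nc21` the entry is "not determined" (no result reported), and for compound 2 `CCC(c1ccc2ncccc2c1F)n1cnc2ncc(-c3ccccc3)nc21` it is "not determined" (no result reported).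

The next compound to be measured is compound 4 `CCC(c1ccc2ncccc2c1F)n1cnc2ncc(-c3ccc(C(N)=O)c(F)c3)nc21`. The change from compound 3 is a group of 11 heavy atoms (9 carbon, 1 nitrogen, 1 fluorine; one six-membered aromatic ring of carbon only, one six-membered aromatic ring with 1 hetero atom) in place of a group of 11 heavy atoms (9 carbon, 1 nitrogen, 1 fluorine; one six-membered aromatic ring of carbon only, one six-membered aromatic ring with 1 hetero atom), on a saturated chain carbon bound to an aromatic nitrogen and a saturated chain carbon. The two compounds contain the same atoms, joined differently, so the swapped groups have identical counts and only their arrangement differs.

For the measured compounds named here, no measured pair shows what such a swap does in this assay, so neither the size nor the direction of the step can be read from the data. Compound 1 and compound 2 carry the same group as compound 4, but they differ from it elsewhere and give no number. That recurrence supports only a weak lean towards a stronger inhibitor, and a result on the weaker side would not be surprising.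

A moderate gain is expected a 3.8-fold lower number from compound 3 to compound 4 (0.58 log units; beyond the scatter), with considerable uncertainty. The estimate for compound 4 is 60 nM, with an expected range of 8 nM to 400 nM.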

Compound 4, half-maximal inhibitory concentration: 665 nM
Beside the measured number, compound 4's estimate is 11-fold (1.04 log units) below it; the whole stated range lies below it.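

This position responds to arrangement alone: this assay records a 2.9-fold higher number from compound 3 to compound 4 (0.47 log units; beyond the scatter), even though the group on the saturated chain carbon keeps the same atoms, the same two aromatic rings and the same counts of hydrogen-bond donors and acceptors. Among the compounds shown here, a list of atoms is therefore not enough to describe this group, since how those atoms are joined also affects the result, and of these two arrangements the one in compound 3 gives the stronger inhibitor. No measurement at hand offers an explanation for this step.

Going by these compounds, compound 1 and compound 2 have no numbers, so their steps cannot be read, and the contribution of the amide and the fluorine on the ring that carries them stays unknown. Also open, on these data alone, is whether this preference for the arrangement in compound 3 would hold if a carboxylic acid replaced the amide, or if a longer chain were attached to the saturated chain carbon.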